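The source may report more compounds than this note shows. Statements on the series, on what has been measured and on what is new or still open speak of the compounds shown alone.

Of the compounds shown here, three of a shared core have been measured in an assay on IMR-32 cells for displacement of a labelled ligand from corticotropin-releasing factor receptor 1 (Homo sapiens), read by scintillation counting, with a stated time of 2 h; on this read-out higher numbers stand for weaker inhibition and lower numbers for stronger inhibition. Compound 1 `CCc1nc(-c2ccc(OC)cc2OC(F)(F)F)c(CC)nc1NC(CC)CC` gives 4.1 nM in this assay, compound 3 `CCc1nc(-c2ccc(OC)cc2C(F)(F)F)c(CC)nc1NC(CC)CC` gives 4.4 nM, and compound 2 `CCc1nc(-c2ccc(Cl)cc2Cl)c(CC)nc1NC(C1CC1)C1CC1` gives 3.7 nM. Within the data shown here, the one step between measured neighbours, a 1.1-fold higher number from compound 1 to compound 3 (0.03 log units; within the scatter), leaves the numbers where they were. Compound 2 holds the lowest of the three numbers, but its gaps to compound 1 and to compound 3 lie within the scatter, so nothing separates the three.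

Compound 4 `CCc1nc(-c2ccc(Cl)cc2Cl)c(CC)nc1SC(C)CC` differs from compound 2 in one place: (sec-butyl)sulfanyl in place of (dicyclopropylmethyl)amino on an aromatic carbon. Among the measured compounds shown here, no measured step touches this position; the only measured step concerns the aromatic ring carrying the trifluoromethyl or trifluoromethoxy group, and so it says nothing about the change at hand. The expectation therefore rests on the bare fact that compound 2 gives 3.7 nM and that a smaller group without a hydrogen-bond donor replaces a larger one. A modest loss is expected, namely a 5.4-fold higher number from compound 2 to compound 4 (0.73 log units; beyond the scatter), and compound 4 is estimated at 20 nM, within a range from 5 nM to 80 nM.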

Compound 4, inhibition constant: 401 nM
Estimate against measurement, compound 4: 20-fold (1.30 log units) below; measured number outside the range, above it.
By their numbers in this assay, from the lowest: compounds 2, 1 and 3 (each within the scatter of the next); then compound 4.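

The earlier compounds shown here all carry a nitrogen-linked group at this position, so they gave no sign of how much it matters. On this aromatic carbon next to the ring nitrogen, putting (sec-butyl)sulfanyl in place of (dicyclopropylmethyl)amino gives a 110-fold higher number from compound 2 to compound 4 (2.03 log units; beyond the scatter) in this assay, which shows that the position is far from indifferent to this change. The step alters several things at once, replacing nitrogen with sulfur, removing the hydrogen-bond donor and both three-membered rings, and reducing the heavy-atom count, and no evidence shown assigns the loss to any one of these.

The compounds shown leave open whether a (sec-butyl)amino group would stay close to compound 2 or a (dicyclopropylmethyl)sulfanyl group would recover its number. They also leave open how an ether oxygen link would fare at this position.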